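The source may hold more compounds than are shown below. What is called first, only, known or untested is meant among the compounds shown, and "the series" means these compounds.

Of the compounds shown here, three sharing one core have been measured in a functional assay on HepG2 cells (Homo sapiens) for antiproliferative activity, read by MTT assay, with a stated time of 48 h; on this read-out higher numbers stand for weaker inhibition and lower numbers for stronger inhibition: compound 1 `CCOc1ccc(NC(=O)Nc2cccc(CNc3nccnc3Cl)c2)cc1` gives 7050 nM, compound 2 `Cc1ccc(NC(=O)Nc2cccc(CNc3nccnc3Cl)c2)c(C)c1` gives 9290 nM, and compound 3 `O=C(Nc1cccc(CNc2nccnc2Cl)c1)Nc1ccccc1F` gives 10500 nM. Compound 1 therefore sits within the usual scatter of both other compounds, and these data cannot separate the three.

The next compound, still unmeasured, is compound 4 `O=C(Nc1ccc(C(F)(F)F)cc1)Nc1cccc(CNc2nccnc2Cl)c1`. It keeps the core of compound 1 but has trifluoromethyl in place of ethoxy on an aromatic carbon, para to a large group (trifluoromethyl in place of ethoxy on an aromatic carbon).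

The most relevant evidence comes from swapping the aromatic group on the amide-type nitrogen. Replacing 4-ethoxyphenyl with 2,4-dimethylphenyl gives a 1.3-fold higher number from compound 1 to compound 2 (0.12 log units; within the scatter), and replacing it with 2-fluorophenyl gives a 1.5-fold higher number from compound 1 to compound 3 (0.17 log units; within the scatter). Exchanging those two newer groups gives a 1.1-fold higher number from compound 2 to compound 3 (0.05 log units; within the scatter). All three steps lie within the scatter. For the measured compounds named here, no measured compound carries trifluoromethyl, however, so this guidance is only indirect.

On this evidence, no step beyond the scatter is expected in this assay, and no clear direction can be called. The estimated step is a 1.1-fold higher number from compound 1 to compound 4 (0.05 log units; within the scatter). For compound 4 the estimated value is 8000 nM, with an expected range from 3500 nM to 18000 nM.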

Compound 4, half-maximal inhibitory concentration: 5050 nM
Beside the measured number, compound 4's estimate is 1.6-fold (0.20 log units) above it, and the stated range covers the measured number.
By their numbers in this assay, from the lowest: compounds 4, 1, 2 and 3 (each within the scatter of the next, the first and the last beyond it).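

Putting trifluoromethyl in place of ethoxy on an aromatic carbon, para to a large group, gives in this assay a 1.4-fold lower number from compound 1 to compound 4 (0.14 log units; within the scatter). The earlier steps shown here swapped one whole aromatic group for another, with substituents in different places, whereas this step changes a single group at a single place and leaves the rest of compound 1 untouched. It shows that this place accepts two quite different groups without a step beyond the scatter: ethoxy has two carbons, one oxygen and one hydrogen-bond acceptor, while trifluoromethyl has one carbon, three fluorines and no hydrogen-bond acceptor, yet the data here give no reason for this outcome.

As far as these compounds go, it remains open whether an amine, a carboxylic acid or a longer chain such as butoxy on this same aromatic carbon would move the number beyond the scatter, or would stay as close to compound 1 as this change did. From the compounds shown here alone, it is also open what plain hydrogen at this place would give, and that comparison would show whether either ethoxy or trifluoromethyl matters at all here.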